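The compounds below may be only part of what the source reports. "The series", "measured", "known", "first", "only" and "open" are said of these compounds alone.

Of the compounds shown here, three sharing one core have been measured in a physicochemical assay for solubility, with a stated time of 18 h, at pH 7.4; a higher number here means a more soluble compound, a lower number a less soluble compound. Compound 1 `c1ccc(-c2ccc3c(NCCCNCc4ccco4)ccnc3c2)cc1` gives 32000 nM. Compound 2 `CC(C)CCc1ccc2c(NCCCNCc3ccco3)ccnc2c1` gives 4200 nM. Compound 3 `Fc1ccc(Cc2ccc3c(NCCCNCc4ccco4)ccnc3c2)c(Cl)c1` gives 4200 nM. Compound 3 stands level with compound 2 at the digits shown, the two together holding the lowest of the three numbers; the step of no change at the digits printed from compound 2 to compound 3 (within the scatter) is within the scatter, whereas a 7.6-fold lower number from compound 1 to compound 2 (0.88 log units; beyond the scatter) and a 7.6-fold lower number from compound 1 to compound 3 (0.88 log units; beyond the scatter) both lie beyond it.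

Compound 4 `COc1ccc(-c2ccc3c(NCCCNCc4ccco4)ccnc3c2)cc1` has not yet been measured. 4-methoxyphenyl in place of 2-chloro-4-fluorobenzyl on an aromatic carbon Of the measured steps, a 7.6-fold lower number from compound 1 to compound 3 (0.88 log units; beyond the scatter) bears most on this change: it records what replacing phenyl with 2-chloro-4-fluorobenzyl did, and the move to compound 4 undoes that replacement while setting a methoxy group on the phenyl. Among the measured compounds shown here, compound 1 carries phenyl at that aromatic carbon and gives 32000 nM, so a return toward that number is expected rather than a stay at the level of compound 3, though the methoxy group has no measured counterpart here and leaves the size uncertain. The account therefore expects a 6.0-fold higher number from compound 3 to compound 4 (0.77 log units; beyond the scatter). For compound 4 the estimated value in this assay is 25000 nM, with a range from 8000 nM to 80000 nM.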

Compound 4, solubility: 32000 nM
For compound 4 the middle estimate is 1.3-fold (0.11 log units) below the measured one; the measured number falls inside the stated range.
By their numbers in this assay, from the lowest: compounds 2 and 3 (each within the scatter of the next); then compounds 1 and 4 (each within the scatter of the next).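

In this assay the step of no change at the digits printed from compound 1 to compound 4 (within the scatter) shows that a methoxy group can be set on the phenyl at this position, on an aromatic carbon of the shared core, and the number stays level with that of the unsubstituted phenyl. With a 7.6-fold higher number from compound 3 to compound 4 (0.88 log units; beyond the scatter) and a 7.6-fold higher number from compound 2 to compound 4 (0.88 log units; beyond the scatter) alongside it, the earlier split now has two compounds on each side: in all four compounds, the aromatic ring joined directly to the core goes with the higher numbers (compound 1 and compound 4), while the groups joined through a saturated carbon, isopentyl and 2-chloro-4-fluorobenzyl, go with the lower numbers (compound 2 and compound 3). Nothing at hand gives a measured reason for this split.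

The compounds shown leave open whether the link to the core or the chlorine and fluorine on the ring separates compound 3 from compound 4, a question that plain benzyl and 2-chloro-4-fluorophenyl at this position would address. They also leave open whether the level seen with methoxy holds for other groups on that phenyl, such as a carboxylic acid or an amine.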